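From compound 2 to a chlorinated four-membered ring

This account rests on a few compounds, and the source may have more. Where it says the series, first, only, none or still open, it means among the compounds named here.

compound 1 `c1ccc2c(c1)CCC2CCN1CCN(c2cccc3c2OCCO3)CC1`: 1.29 mg/kg
compound 2 `C1=C(CCN2CCN(c3cccc4c3OCCO4)CC2)c2ccccc2C1`: 0.45 mg/kg
compound 3 `C1=C(CCN2CCN(c3cccc4c3OCCO4)CC2)c2ccccc2CCC1`: 5.02 mg/kg

In a functional assay on the whole organism for antagonist activity, with Rattus norvegicus as the target (a higher number here means that more compound is needed for the effect, a lower number that less compound is needed), compound 2 has the lowest number of the three measured compounds, at 0.45 mg/kg. Compound 4 `Clc1cccc2c1CC2CCN1CCN(c2cccc3c2OCCO3)CC1` has not yet been measured. It differs from compound 2 as follows: a group of 9 heavy atoms (8 carbon, 1 chlorine; one four-membered non-aromatic ring of carbon only, one six-membered aromatic ring of carbon only) in place of a group of 9 heavy atoms (9 carbon; one five-membered non-aromatic ring of carbon only, one six-membered aromatic ring of carbon only), on a saturated chain carbon, two bonds along the chain from an amine nitrogen in a ring. The group that leaves holds a five-membered non-aromatic ring and a double bond outside aromatic rings, while the group that enters holds a four-membered non-aromatic ring and chlorine.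

Among the compounds with values here, the one measured step at this place is a 2.9-fold lower number from compound 1 to compound 2 (0.46 log units; beyond the scatter), a modest change. Compound 3, with another group there, gives 5.02 mg/kg, so both other measured groups give higher numbers than compound 2. Within the data shown here, no measured compound carries chlorine or a four-membered non-aromatic ring, so this guide is loose. A moderate rise in this assay is therefore expected, on the scale of the step to compound 2 from compound 1. The expected step is a 3.1-fold higher number from compound 2 to compound 4 (0.49 log units; beyond the scatter). Compound 4 is estimated at 1.4 mg/kg, with an expected range from 0.4 mg/kg to 5.5 mg/kg.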

Compound 4, dose for 50% inhibition: 1.13 mg/kg
Beside the measured number, compound 4's estimate is 1.2-fold (0.09 log units) above it; the measured number falls inside the stated range.
By their numbers in this assay, from the lowest: compound 2; then compounds 4 and 1 (each within the scatter of the next); then compound 3.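

In this assay, the group with a four-membered non-aromatic ring and chlorine gives a 2.5-fold higher number from compound 2 to compound 4 (0.40 log units; beyond the scatter), so the group with a five-membered non-aromatic ring and a double bond outside aromatic rings keeps the lowest number among these three compared groups of 9 heavy atoms. The other comparison is a 1.1-fold lower number from compound 1 to compound 4 (0.06 log units; within the scatter), so at this place the group with the four-membered ring and chlorine cannot be told apart from the five-membered group without that double bond. The material at hand offers no evidence on what lies behind either step.

Since the ring size and chlorine change together in compound 4, the compounds shown do not separate their contributions. They also leave open how a four-membered ring group without chlorine, or one carrying fluorine or a methoxy group instead, would read in this assay.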